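The source may report more compounds than this note shows. Statements on the series, on what has been measured and on what is new or still open speak of the compounds shown alone.

Compound 1 `CN(Cc1ccc(OCCCNC(=N)N)cc1)c1nc2ccc(Oc3ccc(C(F)(F)F)cc3)cc2s1` gives 212000 nM in an assay on cells for inhibition of Voltage-dependent T-type calcium channel subunit alpha-1H (Homo sapiens), read by FLIPR and calcium flux, with stated times of 600 s and 300 s; a lower number here means a stronger inhibitor, a higher number a weaker inhibitor.
Compound 2 `CN(Cc1ccc(OCCCNC(=N)N)cc1)c1nc2ccc(Oc3ccc(F)cc3)cc2s1` gives 521000 nM in this assay.
Compound 3 `CN(Cc1ccc(OCCCN)cc1)c1nc2ccc(Oc3ccc(F)cc3)cc2s1` gives 492000 nM in this assay.

All three numbers are large, so none of these compounds inhibits strongly. Compound 2 has the highest number of the three, but compound 3 lies within the usual scatter of it, so the two cannot be told apart. Going by the values given here, the only step beyond the scatter is a 2.5-fold higher number from compound 1 to compound 2 (0.39 log units; beyond the scatter), a swap at one carbon of the outer aromatic ring. The other step, a 1.1-fold lower number from compound 2 to compound 3 (0.02 log units; within the scatter), shows that trimming the chain end on the amine nitrogen made no difference of note.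

Compound 4 `CN(Cc1ccc(OCCCNC(=N)N)cc1)c1nc2ccc(Oc3ccc(O)cc3)cc2s1` differs from compound 2 in one place: hydroxy in place of fluoro on an aromatic carbon. Among the compounds with values here, this change sits on the same aromatic carbon that was altered in the step from compound 1 to compound 2, and that step is the only guide here, since no measured pair swaps fluoro for hydroxy. Because a 2.5-fold higher number from compound 1 to compound 2 (0.39 log units; beyond the scatter) was modest, a change of similar modest size is expected for compound 4, in either direction, and a step within the scatter is about as likely as one just beyond it. Compound 4 is therefore expected to give roughly 450000 nM, within a range of 180000 nM to 1100000 nM. The expected step is a 1.2-fold lower number from compound 2 to compound 4 (0.06 log units; within the scatter).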

Compound 4, half-maximal inhibitory concentration: 332000 nM
Beside the measured number, compound 4's estimate is 1.4-fold (0.13 log units) above it, within the range that was stated.
By their numbers in this assay, from the lowest: compounds 1, 4, 3 and 2 (each within the scatter of the next, the first and the last beyond it).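

In this assay, hydroxy on this aromatic carbon, para to a large group, can be compared with two other groups at the same place: a 1.6-fold lower number from compound 2 to compound 4 (0.20 log units; within the scatter), and a 1.6-fold higher number from compound 1 to compound 4 (0.19 log units; within the scatter). Compound 4 thus cannot be told apart from either compound 1 or compound 2, even though those two differ from each other beyond the scatter, so its hydroxy, with the hydrogen-bond donor and acceptor that fluoro lacks, brings no clear change from either neighbouring group. No measurement is available here that would explain this result.

The compounds shown leave open whether an amine, a carboxylic acid or a methoxy on this same carbon would give a number clearly apart from those of compound 1, compound 2 and compound 4, all of which remain large. They also leave open whether hydroxy in place of fluoro would give a similarly small step on compound 3, whose chain ends in an amine rather than a guanidine.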